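From 2-carboxycyclopropyl to 2-carboxyethenyl

The source may report more compounds than this note shows. Statements on the series, on what has been measured and on what is new or still open speak of the compounds shown alone.

In an ADME assay on the whole organism (strain CD-1) for pharmacokinetics, with Mus musculus as the target, at a dose of 3 mg/kg by the intravenous route (a lower number here means less compound in the circulation, a higher number more compound in the circulation at the dose given), compound 3 (`CN(Cc1ccccc1OCCC[C@@H]1C[C@H]1C(=O)O)C(=O)c1ccc(-c2ccco2)cc1`) gives 40500 ng.h/mL while compound 1 (`CN(Cc1ccccc1OCCCCC(C)(C)C(=O)O)C(=O)c1ccc(-c2ccco2)cc1`) gives 48400 ng.h/mL and compound 2 (`C[C@H](CCCOc1ccccc1CN(C)C(=O)c1ccc(-c2ccco2)cc1)CC(=O)O`) gives 77700 ng.h/mL in the same test. These three values lie within the usual scatter of one another, so compound 3 stands level with both. Compound 4 (`CN(Cc1ccccc1OCCC/C=C/C(=O)O)C(=O)c1ccc(-c2ccco2)cc1`) has 2-carboxyethenyl in place of 2-carboxycyclopropyl on a saturated chain carbon, three bonds along the chain from an oxygen on an aromatic ring. Three measured steps at this same place bear on it: a 1.2-fold lower number from compound 1 to compound 3 (0.08 log units; within the scatter) and a 1.9-fold lower number from compound 2 to compound 3 (0.28 log units; within the scatter) with the ring entering, and a 1.6-fold higher number from compound 1 to compound 2 (0.21 log units; within the scatter) between open chains. Each stayed within the scatter, so no step beyond it is expected here. The step expected in this assay is a 1.2-fold higher number from compound 3 to compound 4 (0.09 log units; within the scatter) and would be hard to tell from no change. Compound 4 is estimated at 50000 ng.h/mL (range 22000 ng.h/mL to 110000 ng.h/mL).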

Compound 4, area under the concentration-time curve: 750 ng.h/mL
For compound 4 the middle estimate is 67-fold (1.82 log units) above the measured one, outside the stated range (below it).
By their numbers in this assay, from the lowest: compound 4; then compounds 3, 1 and 2 (each within the scatter of the next).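

For the compounds shown here, at this place, on a saturated chain carbon, three bonds along the chain from an oxygen on an aromatic ring, the end group can matter far more than the earlier compounds showed. In this assay the change to 2-carboxyethenyl gives a 54-fold lower number from compound 3 to compound 4 (1.73 log units; beyond the scatter) and a 100-fold lower number from compound 2 to compound 4 (2.02 log units; beyond the scatter) and also a 65-fold lower number from compound 1 to compound 4 (1.81 log units; beyond the scatter). No measurement shown accounts for this drop. On these data alone, it remains open whether a plain 2-carboxyethyl group, with no double bond outside the carboxylic acid, would stand with compound 1, compound 2 and compound 3 or with compound 4.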